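The source may report more compounds than this note shows. Statements on the series, on what has been measured and on what is new or still open speak of the compounds shown alone.

Measured compounds in a functional assay on PC-3 cells (Homo sapiens) for inhibition; on this read-out lower numbers stand for stronger inhibition and higher numbers for weaker inhibition:
compound 1, `COc1ccc(C(=O)N2CCN(c3nc(N)c4cc(OC)c(OC)cc4n3)CC2)cc1OC`: 71000 nM
compound 2, `COc1cc2nc(N3CCN(C(=O)c4ccc(C(C)(C)C)cc4)CC3)nc(N)c2cc1OC`: 47000 nM
compound 3, `COc1cc2nc(N3CCN(S(=O)(=O)c4ccc([N+](=O)[O-])cc4)CC3)nc(N)c2cc1OC`: 36000 nM

In this assay compound 3 shows the lowest of the three numbers, though its gaps to compound 2 and to compound 1 both lie within the scatter, so no order among them can be read. Compound 4, `COc1cc2nc(N3CCN(S(=O)(=O)c4ccc(C(=O)O)cc4)CC3)nc(N)c2cc1OC`, differs from compound 3 by carboxy in place of nitro on an aromatic carbon. Among the measured compounds shown here, the only measured step, a 1.5-fold lower number from compound 1 to compound 2 (0.18 log units; within the scatter), concerns an aryl group on a carbonyl carbon and not a nitro-to-carboxy exchange, so it does not bear on this change. For the measured compounds named here, with no comparable step to draw on, a step of a 1.1-fold higher number from compound 3 to compound 4 (0.05 log units; within the scatter) is expected, that is nothing beyond the scatter. Compound 4 is therefore estimated at 40000 nM, with a range from 14000 nM to 120000 nM.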

Compound 4, half-maximal inhibitory concentration: 53000 nM
Compound 4: the middle estimate sits 1.3-fold (0.12 log units) below what was measured; the measured number falls inside the stated range.
By their numbers in this assay, from the lowest: compounds 3, 2, 4 and 1 (each within the scatter of the next).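

In this assay the exchange of nitro for carboxy on this aromatic carbon, para to a large group, gives a 1.5-fold higher number from compound 3 to compound 4 (0.17 log units; within the scatter) and so stays within the scatter. This is the only reading of a change at this position among the compounds shown, and here the two groups cannot be told apart, although carboxy carries a hydrogen-bond donor that nitro lacks. No measurement at hand explains the result. Going by these compounds, whether an amine or a methyl ester at this place would move the number beyond the scatter remains open.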